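The compounds below may be only part of what the source reports. "The series", "measured", "known", "first", "only" and "open" are said of these compounds alone.

Measured so far in an assay on isolated protein for binding affinity to Leucine-rich repeat serine/threonine-protein kinase 2 variant G2019S (Homo sapiens), read by TR-FRET and LanthaScreen, with a stated time of 2 h; on this read-out lower numbers stand for stronger inhibition and higher numbers for weaker inhibition: compound 1 `C[C@@H]1CCCN1c1c(C#N)c2c(N)ncnc2n1C` gives 0.7 nM; compound 2 `C[C@@H]1CCCN1c1[nH]c2ncnc(N)c2c1C#N` gives 14 nM; compound 3 `Cc1n[nH]cc1Nc1nc(N)c2c(C#N)c(N3CCC[C@H]3C)n(C)c2n1` gives 2 nM.

From compound 2 to compound 1 the change methyl in place of hydrogen on an aromatic nitrogen brings a 20-fold lower number from compound 2 to compound 1 (1.30 log units; beyond the scatter). From compound 1 to compound 3 the change is (3-methyl-1H-pyrazol-4-yl)amino in place of hydrogen on an aromatic carbon, giving a 2.9-fold higher number from compound 1 to compound 3 (0.46 log units; beyond the scatter). The difference between the cores of compound 2 and compound 3 is not broken down here.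

Compound 4 `Cc1nn(C)cc1Nc1nc(N)c2c(C#N)c(N3CCC[C@H]3C)n(C)c2n1` differs from compound 3 by methyl in place of hydrogen on an aromatic nitrogen. This is the same kind of change as that from compound 2 to compound 1, but at a different place: there the nitrogen sits in a five-membered aromatic ring with 1 nitrogen, part of a fused system, next to the ring atom bearing the 2-methylpyrrolidin-1-yl group; here it sits in a five-membered aromatic ring with 2 nitrogen, two ring bonds from the ring atom that bears a large group. The earlier step was on the shared core itself, so it is not taken as a guide for the size here; a step close to the scatter is expected from compound 3 to compound 4, no change at the digits printed from compound 3 to compound 4 (within the scatter). For compound 4 in this assay the estimate is 2 nM, expected between 0.6 nM and 7 nM.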

Compound 4, inhibition constant: 2 nM
Estimate against measurement, compound 4: no gap at the digits printed, within the range that was stated.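

In this assay, methyl in place of hydrogen on an aromatic nitrogen does not give a step of one size in the two settings: the same change on two cores in this assay, a 20-fold lower number (1.30 log units; beyond the scatter) from compound 2 to compound 1 and no change at the digits printed (within the scatter) from compound 3 to compound 4, 20-fold (1.30 log units) apart, beyond the scatter of two such steps On the pyrazole nitrogen the change gives no change at the digits printed from compound 3 to compound 4 (within the scatter), and the (1,3-dimethyl-1H-pyrazol-4-yl)amino group gives a 2.9-fold higher number from compound 1 to compound 4 (0.46 log units; beyond the scatter). This shows that the size of the step on the shared core cannot be carried over to the pyrazole nitrogen, but it does not give a reason, and the two steps sit at different nitrogens, so neither tests one position on two cores.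

Open, on these data alone, is how larger groups on the pyrazole nitrogen, such as ethyl, cyclopropyl or a chain ending in an amine, would read. Also open, as far as these compounds go, is whether the same flat result would hold with chloro in place of the methyl group on that ring.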